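Swapping 3-chlorophenyl for 4-chlorophenyl on a shared core

This account rests on a few compounds, and the source may have more. Where it says the series, first, only, none or still open, it means among the compounds named here.

In a functional assay on K562 cells (Homo sapiens) for cytotoxicity, read by ELISA, with a stated time of 4 days (on this read-out higher numbers stand for weaker inhibition and lower numbers for stronger inhibition), compound 3 `Clc1cccc(-c2cc(-c3ccc(Cl)o3)cc(-c3ccc(Cl)s3)n2)c1` gives 19600 nM and shares those digits with compound 2 `Clc1ccc(-c2cc(-c3ccoc3)cc(-c3ccc(Cl)s3)n2)cc1` at 19600 nM while compound 1 `Clc1ccc(-c2cc(-c3ccco3)cc(-c3ccc(Cl)s3)n2)cc1` gives 10500 nM and all three lie within the usual scatter of one another.

Compound 4 `Clc1ccc(-c2cc(-c3ccc(Cl)o3)cc(-c3ccc(Cl)s3)n2)cc1` differs from compound 3 at one place only, which is 4-chlorophenyl in place of 3-chlorophenyl on an aromatic carbon with 4-chlorophenyl in place of 3-chlorophenyl next to the ring nitrogen.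

For the measured compounds named here, the only measured step is a 1.9-fold higher number from compound 1 to compound 2 (0.27 log units; within the scatter) and it concerns the furan group rather than this place, so no measured pair isolates the change at hand. Still, compound 1 at 10500 nM and compound 2 at 19600 nM already carry 4-chlorophenyl and sit in the same range as compound 3. No step beyond the scatter is therefore expected in this assay for this swap. The estimated change is a 1.3-fold lower number from compound 3 to compound 4 (0.12 log units; within the scatter) and it stays small. For compound 4 the estimated value is 15000 nM with an expected range from 7500 nM to 30000 nM as the likely span.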

Compound 4, half-maximal inhibitory concentration: 19300 nM
Compound 4: middle estimate off by 1.3-fold (0.11 log units), on the low side; the range from low to high includes it.
By their numbers in this assay, from the lowest: compounds 1, 4, 2 and 3 (each within the scatter of the next).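

For the compounds shown here, this is the first direct read on this position, the carbon next to the ring nitrogen: in this assay, moving the chlorine from 3-chlorophenyl to 4-chlorophenyl gives a 1.0-fold lower number from compound 3 to compound 4 (0.01 log units; within the scatter), so the two placements cannot be told apart here. With 4-chlorophenyl held fixed, the furan group can also be compared: 5-chlorofuran-2-yl in place of furan-3-yl gives a 1.0-fold lower number from compound 2 to compound 4 (0.01 log units; within the scatter), and chloro in place of hydrogen on the furan gives a 1.8-fold higher number from compound 1 to compound 4 (0.26 log units; within the scatter), both also within the scatter. Nothing available explains this flat result.

As far as these compounds go, all four compounds carry a chlorophenyl group at this position, so it remains open whether a plain phenyl or 2-chlorophenyl would read differently. An amine or a carboxylic acid on that ring is also untested among the compounds shown, so these results cannot say whether such a group would shift the number beyond the scatter.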